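Hydroxymethyl in Place of Formyl: Compound 2 to Compound 3

The source may report more compounds than this note shows. Statements on the series, on what has been measured and on what is new or still open speak of the compounds shown alone.

compound 1 `OCc1cc(O)c(O)c(Br)c1`: 51500 nM
compound 2 `O=Cc1cc(Br)c(O)c(O)c1Br`: 31000 nM

In a functional assay on DLD-1 cells (Homo sapiens) for cytotoxicity, read by MTT assay, with a stated time of 96 h (a higher number here means a weaker inhibitor, a lower number a stronger inhibitor), compound 2 gives the lowest of the two numbers; compound 1 sits within the scatter of it, so no order between them is drawn. Compound 3 `OCc1cc(Br)c(O)c(O)c1Br` differs from compound 2 in one place: hydroxymethyl in place of formyl on an aromatic carbon. Among the compounds with values here, no pair of measured compounds shows this change, so its size is not known. A modest move toward weaker inhibition is expected, a 1.6-fold higher number from compound 2 to compound 3 (0.21 log units; within the scatter), roughly at the edge of the scatter. Compound 3 is estimated at 50000 nM, in a range from 20000 nM to 120000 nM.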

Compound 3, half-maximal inhibitory concentration: 15000 nM
Compound 3: the middle estimate sits 3.3-fold (0.52 log units) above what was measured, and the stated range ends above it.
By their numbers in this assay, from the lowest: compound 3; then compounds 2 and 1 (each within the scatter of the next).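

Hydroxymethyl in place of formyl on this aromatic carbon gives a 2.1-fold lower number from compound 2 to compound 3 (0.32 log units; beyond the scatter) and so moves toward stronger inhibition, which shows that the position responds to this change. With hydroxymethyl kept, bromo in place of hydrogen on an aromatic carbon gives a 3.4-fold lower number from compound 1 to compound 3 (0.54 log units; beyond the scatter) and is of modest size too. Nothing given here accounts for either step. Still open, on these data alone, is how an amine, a carboxylic acid or a longer chain would read at this position. Also open, as far as these compounds go, is whether the bromo step would hold with formyl in place of hydroxymethyl.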